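A few compounds are considered here, and "the series" means these few. Any claim that something is new, unique, unknown or untested is made for them only; others in the source may bear on it.

Measured compounds:
Compound 1, `COc1ccc2[nH]c(C(=O)N3CC(=O)N(Cc4ccccc4)[C@@H](COCc4ccccc4)C3)cc2c1`, in a physicochemical assay for solubility, read by spectrophotometry, in phosphate buffer, with a stated time of 2 h, at pH 7.4; a higher number here means a more soluble compound, a lower number a less soluble compound: 8800 nM
Compound 2, `COc1ccc2[nH]c(C(=O)N3CC(=O)N(Cc4cccc(OC)n4)[C@@H](Cc4ccccc4)C3)cc2c1`, in this assay: 47500 nM

Of the two measured compounds, compound 1 stands lowest in this assay; the nearest number, that of compound 2, is higher by a margin beyond the usual scatter. For the measured compounds named here, no single-change step between these two compounds has been worked out, so their two values are taken only as they stand. The compound now in question is compound 3, `COc1ccc2[nH]c(C(=O)N3CC(=O)N(Cc4ccccc4)[C@@H](CN4CC5CCCC5C4)C3)cc2c1`. It differs from compound 1 at one place: a group of 8 heavy atoms (7 carbon, 1 nitrogen; one five-membered non-aromatic ring of carbon only, one five-membered non-aromatic ring with 1 hetero atom) in place of a group of 8 heavy atoms (7 carbon, 1 oxygen; one six-membered aromatic ring of carbon only), on a saturated chain carbon bound to a saturated ring carbon. Going by the values given here, no measured pair shows what such a change does, so the expectation rests on the structural change alone. The step is expected to raise solubility, a 6.8-fold higher number from compound 1 to compound 3 (0.83 log units; beyond the scatter), by an amount beyond the scatter. Compound 3 is therefore estimated at 60000 nM, within a range from 15000 nM to 250000 nM.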

Compound 3, solubility: 20700 nM
For compound 3 the middle estimate is 2.9-fold (0.46 log units) above the measured one; low and high end bracket the measured number.
By their numbers in this assay, from the lowest: compound 1; then compound 3; then compound 2.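

In this assay, putting the group of two five-membered non-aromatic rings in place of benzyloxy, on a saturated chain carbon bound to a saturated ring carbon, gives a 2.4-fold higher number from compound 1 to compound 3 (0.37 log units; beyond the scatter). For the compounds shown here, this is the first single-place change that can be read, and it shows that the number moves at this position even though the entering and leaving groups both hold 8 heavy atoms and carry no net charge. No measurement shown here explains the step.

The compounds shown leave open whether the step follows the loss of the aromatic ring, the exchange of oxygen for nitrogen, or the shape of the entering group. A dimethylamino group or a cyclohexylmethoxy group at the same place would begin to separate these possibilities.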